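This account rests on a few compounds, and the source may have more. Where it says the series, first, only, none or still open, it means among the compounds named here.

Measured so far:
compound 1 `COc1ccccc1-c1cc(O)c2cc(C)cnc2n1`: 27500 nM
compound 2 `Cc1cnc2nc(-c3ccc(F)cc3)cc(O)c2c1`: 25100 nM

In a functional assay on U-251 cells (Homo sapiens) (on this read-out lower numbers stand for stronger inhibition of growth and higher numbers for weaker inhibition of growth), compound 1 gives 27500 nM, the higher of the two numbers; compound 2 gives 25100 nM, which lies within the scatter of compound 1, so the two cannot be ordered. Compound 3 `COc1ccccc1-c1cc(O)c2cccnc2n1` differs from compound 1 by hydrogen in place of methyl on an aromatic carbon. Among the measured compounds shown here, no measured pair in this assay shows this change, so the expectation rests on compound 1 alone. The step of a 1.2-fold higher number from compound 1 to compound 3 (0.08 log units; within the scatter) is expected to stay within the scatter. Compound 3 is therefore estimated at 33000 nM, in a range from 14000 nM to 80000 nM.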

Compound 3, concentration for 50% growth inhibition: 67600 nM
Compound 3: the middle estimate sits 2.0-fold (0.31 log units) below what was measured, and the stated range covers the measured number.
By their numbers in this assay, from the lowest: compounds 2 and 1 (each within the scatter of the next); then compound 3.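

Hydrogen in place of methyl on this aromatic carbon, two atoms from the ring nitrogen, gives in this assay a 2.5-fold higher number from compound 1 to compound 3 (0.39 log units; beyond the scatter), the first step in the series that can be read at a single place. It shows that growth inhibition at this position weakens modestly when the methyl leaves, though this rests on one pair alone. Nothing at hand gives a reason for this step. Going by these compounds, whether an ethyl group or an amine on this carbon would do better or worse than methyl stays open. On these data alone, it also stays open whether the same step would appear on compound 2, which carries the same methyl.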